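The source may report more compounds than this note shows. Statements on the series, on what has been measured and on what is new or still open speak of the compounds shown alone.

Compound 1 `CS(=O)(=O)c1ccc(-c2nc(SCCCOC(=O)/C=C/c3ccc(O)c(O)c3)nn2-c2ccc(Br)cc2)cc1` and compound 2 `CS(=O)(=O)c1ccc(-c2nc(SCCCOC(=O)/C=C/c3ccc(O)c(O)c3)nn2-c2ccc(F)cc2)cc1` are built on one shared core, while compound 3 `CC(=O)Oc1ccc(/C=C/C(=O)NCCCSc2nc(-c3ccc(S(C)(=O)=O)cc3)n(-c3ccc(Br)cc3)n2)cc1OC(C)=O` and compound 4 `CC(=O)Oc1ccc(/C=C/C(=O)NCCCSc2nc(-c3ccc(S(C)(=O)=O)cc3)n(-c3ccc(F)cc3)n2)cc1OC(C)=O` are built on another; the difference between the two cores is not broken down here. In a functional assay on PC-3 cells (Homo sapiens) for antiproliferative activity, read by MTT assay, with a stated time of 72 h (on this read-out lower numbers stand for stronger inhibition and higher numbers for weaker inhibition), compound 1 gives 12400 nM, and in this assay compound 2 gives 10100 nM. Among the measured compounds shown here, the only change between these two, (fluoro in place of bromo on an aromatic carbon), produced a 1.2-fold lower number from compound 1 to compound 2 (0.09 log units; within the scatter). In this assay compound 3 gives 23900 nM. The same change, (fluoro in place of bromo on an aromatic carbon), leads from compound 3 to compound 4, and in both pairs it sits at the same place on the ring. Since the earlier step stayed within the scatter, the step from compound 3 to compound 4 in this assay is expected to be small as well, a 1.2-fold lower number from compound 3 to compound 4 (0.08 log units; within the scatter), an expectation that rests on a 1.2-fold lower number from compound 1 to compound 2 (0.09 log units; within the scatter) between compound 1 and compound 2. Compound 4 is therefore estimated at 20000 nM, with most repeated measurements expected to fall between 10000 nM and 45000 nM.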

Compound 4, half-maximal inhibitory concentration: 17600 nM
The estimate for compound 4 lay 1.1-fold (0.06 log units) above the measured number; low and high end bracket the measured number.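

In this assay, replacing 4-bromophenyl with 4-fluorophenyl gives a 1.4-fold lower number from compound 3 to compound 4 (0.13 log units; within the scatter), so this step, like the earlier one, is too small to separate from ordinary repeat-to-repeat variation. Set side by side, the two steps agree, and the change behaves alike on both cores: the same change on two cores in this assay, a 1.2-fold lower number (0.09 log units; within the scatter) from compound 1 to compound 2 and a 1.4-fold lower number (0.13 log units; within the scatter) from compound 3 to compound 4, 1.1-fold (0.04 log units) apart, within the scatter of two such steps. Among the compounds shown here, this shows that, on these two cores, the swap can be carried across with little change in the number, but it rests on only two pairs and both steps are small, so it does not show that the agreement would hold on a third core or for a change with a larger effect.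

As far as these compounds go, what a group other than bromo or fluoro would do at this place on the ring remains open, for instance chloro, methoxy or trifluoromethyl. Also open, from the compounds shown here alone, is whether the small effect of this swap would persist with a longer chain in the linker, or with an amine or a carboxylic acid on the ring.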